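This account rests on a few compounds, and the source may have more. Where it says the series, first, only, none or still open, it means among the compounds named here.

Measured so far:
- compound 1 `COc1ccc(-c2cc(C(=O)/C=C/c3ccccc3)nc3cc(-c4ccccc4)nn23)cc1OC`: in a functional assay on MDA-MB-231 cells (Homo sapiens) for antiproliferative activity, read by MTT assay, with a stated time of 24 h (on this read-out higher numbers stand for weaker inhibition and lower numbers for stronger inhibition), compound 1 gives 23300 nM
- compound 2 `COc1ccc(-c2cc(C(=O)/C=C/c3ccc(Cl)cc3)nc3cc(-c4ccccc4)nn23)cc1OC`: in this assay compound 2 gives 23700 nM

Within the data shown here, only two numbers are at hand. Among the measured compounds shown here, the one for compound 2 and the one for compound 1 lie within the scatter of each other, so compound 2 stands level with compound 1 rather than apart from it; the single step, a 1.0-fold higher number from compound 1 to compound 2 (0.01 log units; within the scatter), tells the same.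

Compound 3 `COc1ccc(-c2cc(C(=O)/C=C/c3cc(OC)c(OC)c(OC)c3)nc3cc(-c4ccccc4)nn23)cc1OC` is not yet measured. Its change from compound 2 is 3,4,5-trimethoxyphenyl in place of 4-chlorophenyl on a double-bonded chain carbon bound to a double-bonded chain carbon. For the measured compounds named here, the one measured step, a chloro for a hydrogen on that same ring, bears only loosely on it, and it was within the scatter. Nothing measured here speaks to three methoxy groups on that ring, so the expectation rests on the shared core keeping the number in the same region, with wide room for movement either way.

Compound 3 is therefore expected to give about 15000 nM in this assay, somewhere between 3500 nM and 45000 nM, an expected step of a 1.6-fold lower number from compound 2 to compound 3 (0.20 log units; within the scatter).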

Compound 3, half-maximal inhibitory concentration: 16700 nM
Beside the measured number, compound 3's estimate is 1.1-fold (0.05 log units) below it; the measured number falls inside the stated range.
By their numbers in this assay, from the lowest: compounds 3, 1 and 2 (each within the scatter of the next).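

In this assay, putting 3,4,5-trimethoxyphenyl in place of 4-chlorophenyl on a double-bonded chain carbon bound to a double-bonded chain carbon gives a 1.4-fold lower number from compound 2 to compound 3 (0.15 log units; within the scatter) and the same group in place of phenyl gives a 1.4-fold lower number from compound 1 to compound 3 (0.14 log units; within the scatter) at this place. Until now, this place had been tested only with a single chloro on the ring, whereas here a group of 12 heavy atoms and 3 hydrogen-bond acceptors replaces one of 7 heavy atoms and 0 acceptors, and compounds 1, 2 and 3 still stand level with one another. This very different ring therefore leaves the number within the scatter, although nothing available explains this outcome.

The compounds shown leave open whether any group at this place can move the number beyond the scatter, for example a ring carrying an amine or a carboxylic acid, or a longer chain in place of the methoxy groups. They also leave open what changes elsewhere on the shared core would do, as that core stays the same in all three compounds.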